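The source may report more compounds than this note shows. Statements on the series, on what has been measured and on what is new or still open speak of the compounds shown alone.

Compound 1 `CN(C)c1ncnc2c1c(-c1ccsc1)cn2[C@@H]1O[C@H](CO)[C@@H](O)[C@H]1O`: in a functional assay on CCRF-CEM cells (Homo sapiens), read by MTT assay, with a stated time of 72 h (a lower number here means a stronger inhibitor, a higher number a weaker inhibitor), compound 1 gives 3480 nM.
Compound 2 `CN(C)c1ncnc2c1c(-c1cccs1)cn2[C@@H]1O[C@H](CO)[C@@H](O)[C@H]1O`: in this assay compound 2 gives > 20000 nM, which is a limit of the assay and not a number.

Compound 1 thus holds the only number shown; the other value is a limit. For the measured compounds named here, the one measured step, an at least 5.7-fold higher number from compound 1 to compound 2 (0.75 log units; beyond the scatter), moves the thiophene attachment and does not touch the part altered in compound 3 `CSc1ncnc2c1c(-c1ccsc1)cn2[C@@H]1O[C@H](CO)[C@@H](O)[C@H]1O`, where the change is methylsulfanyl in place of dimethylamino on an aromatic carbon. Going by the values given here, no measured step bears on this change, so only a modest step in this assay is expected, probably toward a higher number. Compound 3 is estimated at 6000 nM (range 1500 nM to 20000 nM), an expected step of a 1.7-fold higher number from compound 1 to compound 3 (0.24 log units; within the scatter).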

Compound 3, half-maximal inhibitory concentration: > 20000 nM
Compound 3 was reported as a limit; the forecaster's own chance of this, stated with the estimate: 25%; middle value at least 3.3-fold (0.52 log units) away from the limit.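

In this assay methylsulfanyl in place of dimethylamino on this aromatic carbon gives an at least 5.7-fold higher number from compound 1 to compound 3 (0.75 log units; beyond the scatter) and shows that this position, untouched in the earlier step, also bears on the read-out while thiophen-3-yl stays fixed. The value for compound 3 is a limit of the assay and not a number: the limit of > 20000 nM in this assay, at which 2 of the 3 values shown sit.

From the compounds shown here alone, the full size of this step therefore stays open. Also open, going by these compounds, is whether a primary amine, a methoxy group or a longer chain such as ethylsulfanyl at this position would give a measurable value.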